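This account rests on a few compounds, and the source may have more. Where it says the series, first, only, none or still open, it means among the compounds named here.

Two compounds of the series have numbers in an assay on isolated protein for inhibition of glucokinase regulatory protein (Homo sapiens), read by AlphaScreen, with stated times of 20 min and 4 h; on this read-out lower numbers stand for stronger inhibition and higher numbers for weaker inhibition. Compound 1 `CC#C[C@H]1CN(S(=O)(=O)c2ccc(N)nc2)CCN1c1ncc(C(C)(O)C(F)(F)F)s1` gives 49 nM, the higher of the two numbers, while compound 2 `CC#C[C@H]1CN(S(=O)(=O)c2ccc(N)nc2)CCN1c1ccc(C(O)(CC#N)C(F)(F)F)cc1` gives 28 nM; the gap between them lies within the scatter. Compound 3 `CC#C[C@H]1CN(S(=O)(=O)c2ccc(N)nc2)CCN1c1ncc(C(O)(C(F)(F)F)C(F)(F)F)s1` is not yet measured. It differs from compound 1 by trifluoromethyl in place of methyl on a saturated chain carbon bound to an aromatic carbon, an oxygen on a saturated carbon and a saturated chain carbon. Among the compounds with values here, no step between measured compounds matches this change, so its size is open; a move that stays within the scatter, or at most a slight shift toward lower numbers, is expected, as a 1.2-fold lower number from compound 1 to compound 3 (0.09 log units; within the scatter). Compound 3 is therefore estimated at 40 nM, with a range from 15 nM to 120 nM.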

Compound 3, half-maximal inhibitory concentration: 81 nM
The estimate for compound 3 lay 2.0-fold (0.31 log units) below the measured number, and the stated range covers the measured number.
By their numbers in this assay, from the lowest: compounds 2, 1 and 3 (each within the scatter of the next, the first and the last beyond it).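

In this assay, trifluoromethyl in place of methyl on this saturated chain carbon gives a 1.7-fold higher number from compound 1 to compound 3 (0.22 log units; within the scatter). This first single-place step at the position shows that the exchange of one heavy atom for four leaves the number within the scatter. No measurement available bears on the reason for this result.

Going by these compounds, whether an ethyl group or an amine on this carbon would also stay within the scatter remains open. Compound 2 differs from compound 1 in more than one place, so it cannot settle this.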